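The source may report more compounds than this note shows. Statements on the series, on what has been measured and on what is new or still open speak of the compounds shown alone.

In an assay on cells for inhibition of histone-lysine N-methyltransferase EZH2 (Homo sapiens), read by ELISA, with a stated time of 72 h (on this read-out higher numbers stand for weaker inhibition and lower numbers for stronger inhibition), compound 1 `COc1cc(C)[nH]c(=O)c1CN1CCc2c(Cl)cc(-c3c(C)noc3C)c(Cl)c2C1=O` gives 8 nM. Compound 2 `COc1cc(C)[nH]c(=O)c1CN1CCc2c(Cl)cc([C@H](O)C3COC3)c(Cl)c2C1=O`, in which a group of 6 heavy atoms with one four-membered non-aromatic ring stands in place of a group of 7 heavy atoms with one five-membered aromatic ring on an aromatic carbon, gives 99 nM; among the single numbers shown it is the highest, and the step from one to the other is a 12-fold higher number from compound 1 to compound 2 (1.09 log units; beyond the scatter). Compound 3 `CCOC(c1cc(Cl)c2c(c1Cl)C(=O)N(Cc1c(C)cc(C)[nH]c1=O)CC2)C1CS(=O)(=O)C1` gives 6080 nM; 62 nM (2 entries), and the several entries of compound 3 in this assay, 6080 nM; 62 nM (2 entries) shows how far repeated measurements of one compound can lie apart in this kind of test.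

Compound 4 `COc1cc(C)[nH]c(=O)c1CN1CCc2c(Cl)cc([C@@H](O)C3COC3)c(Cl)c2C1=O` differs from compound 2 only in configuration: the two compounds have the same atoms and bonds and differ only in configuration as drawn: 1 of 1 stereo elements differ; a stereocentre at a saturated chain carbon is drawn R in compound 2 and S in compound 4. Within the data shown here, no measured step matches this kind of change. The step of a 12-fold higher number from compound 1 to compound 2 (1.09 log units; beyond the scatter) exchanges one whole group for another and so says nothing about turning a single stereocentre. Among the measured compounds shown here, two such mirror forms can be equally active or far apart, and nothing among the measured compounds tells which case applies here. The expected step is therefore a 1.5-fold higher number from compound 2 to compound 4 (0.18 log units; within the scatter), carrying a wide range. Compound 4 is expected to give about 150 nM, somewhere between 20 nM and 1500 nM.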

Compound 4, half-maximal inhibitory concentration in the histone-lysine N-methyltransferase EZH2 assay: > 32000 nM
Compound 4: only a limit was reported; the forecaster's own chance of this, stated with the estimate: 5%; middle value at least 210-fold (2.32 log units) away from the limit.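

In the histone-lysine N-methyltransferase EZH2 assay, turning this one stereocentre produces an at least 320-fold higher number from compound 2 to compound 4 (2.50 log units; beyond the scatter), far more than the earlier exchange of a whole group, a 12-fold higher number from compound 1 to compound 2 (1.09 log units; beyond the scatter), and this gap can be traced only to the configuration because nothing else differs between the two compounds: the fact that compounds 2 and 4 differ only in the configuration as drawn

The exchange of the five-membered aromatic ring group for the group of 6 heavy atoms now appears as an at least 4000-fold higher number from compound 1 to compound 4 (3.60 log units; beyond the scatter), so the size of that exchange depends strongly on how the new group's stereocentre is drawn, something compound 2 alone could not show.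

In the histone-lysine N-methyltransferase EZH2 assay compound 4 gives > 32000 nM, which is a limit and not a number, so its true distance from the other compounds remains unknown: the limit of > 32000 nM in the histone-lysine N-methyltransferase EZH2 assay, at which 1 of the 4 values shown sits.

On these data alone, whether an amine or a carboxylic acid at this stereocentre would show a similar gap between its two drawn forms remains open. In a physicochemical assay for solubility, measured as kinetic solubility (on this read-out higher numbers stand for higher solubility and lower numbers for lower solubility), compound 2 gives 234000 nM and compound 4 gives 582000 nM. In the physicochemical assay, the same turn gives only a 2.5-fold higher number from compound 2 to compound 4 (0.40 log units; beyond the scatter), and this single pair cannot show whether solubility and inhibition are connected at this position.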